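Replacing a Methoxyphenyl Amide Group with a Bromomethylphenyl One

A few compounds are considered here, and "the series" means these few. Any claim that something is new, unique, unknown or untested is made for them only; others in the source may bear on it.

Of the compounds shown here, two that share a common core have been measured in an assay on isolated protein for inhibition of histone deacetylase 4 (Homo sapiens), with a stated time of 1 h; on this read-out higher numbers stand for weaker inhibition and lower numbers for stronger inhibition. Compound 1 `CCOc1ccc2nc(NC(=O)COc3ccc4cc(/C=C5/SC(=O)NC5=O)ccc4c3)sc2c1` gives 3600 nM in this assay. Compound 2 `COc1cccc(NC(=O)COc2ccc3cc(/C=C4/SC(=O)NC4=O)ccc3c2)c1` gives 1600 nM in this assay, the lowest of the two numbers, and its gap to compound 1 lies beyond the scatter, so compound 2 stands as the stronger inhibitor of the pair. Compound 3 `Cc1cc(Br)ccc1NC(=O)COc1ccc2cc(/C=C3/SC(=O)NC3=O)ccc2c1` has not yet been measured. It differs from compound 2 in one place: 4-bromo-2-methylphenyl in place of 3-methoxyphenyl on an amide-type nitrogen. Going by the values given here, no step of this kind between measured compounds is available, so the measured pair says nothing about how this assay answers to the change. The group that enters matches the group that leaves in size, and the amide-type nitrogen and its carbonyl neighbour stay in place. Across this change the step is expected to be small, within the scatter and in no settled direction: a 1.1-fold higher number from compound 2 to compound 3 (0.05 log units; within the scatter). Compound 3 is therefore expected to give 1800 nM in this assay, within a range from 600 nM to 5000 nM.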

Compound 3, half-maximal inhibitory concentration: 550 nM
Beside the measured number, compound 3's estimate is 3.3-fold (0.51 log units) above it; measured number below the stated range.
By their numbers in this assay, from the lowest: compound 3; then compound 2; then compound 1.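

In this assay, the step of a 2.9-fold lower number from compound 2 to compound 3 (0.46 log units; beyond the scatter) shows that this position on the amide-type nitrogen responds to the choice of aromatic group, even when the incoming group matches the outgoing one in heavy-atom count and keeps the same six-membered carbon ring. It also shows that the stronger inhibition of the pair goes with the 4-bromo-2-methylphenyl group, which has bromine where the 3-methoxyphenyl group has oxygen and carries no hydrogen-bond acceptor where the group that leaves carries one. Nothing shown here gives a measured property that bears on this step, so the reason for it remains unknown.

Since the methoxy group leaves and the bromine and methyl enter in one step, the compounds shown cannot tell whether the bromine, the methyl or the pair of them goes with the lower number. Also open, as far as these compounds go, is how the assay would answer to a ring carrying only the bromine or only the methyl, to a plain phenyl ring, or to a ring bearing a chlorine, an amine or a carboxylic acid at this position.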